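Compound 3 and a rearranged difluorophenyl group

The source may report more compounds than this note shows. Statements on the series, on what has been measured and on what is new or still open speak of the compounds shown alone.

In an ADME assay on MT4 cells (Homo sapiens) for cytotoxicity, read by MTT assay (a lower number here means that less compound is tolerated, a higher number that more compound is tolerated), compound 1 (`Cc1ccc(N(C(=O)c2ccc([N+](=O)[O-])cc2)C(=S)OCCN2C(=O)c3ccccc3C2=O)cc1`) gives 58000 nM, compound 2 (`O=C1c2ccccc2C(=O)N1CCOC(=S)N(C(=O)c1c(F)cccc1F)c1ccc(Cl)cc1`) gives 39000 nM and compound 3 (`Cc1ccc(N(C(=O)c2ccc(F)cc2F)C(=S)OCCN2C(=O)c3ccccc3C2=O)cc1`) gives 20000 nM. Compound 3 and compound 2 lie within the scatter of each other, while compound 1 stands clear of compound 3, as the modest step of a 2.9-fold lower number from compound 1 to compound 3 (0.46 log units; beyond the scatter) shows. Compound 4 (`Cc1ccc(N(C(=O)c2c(F)cccc2F)C(=S)OCCN2C(=O)c3ccccc3C2=O)cc1`) carries 2,6-difluorophenyl in place of 2,4-difluorophenyl on a carbonyl carbon. That measured step involved a different group, so it bears only loosely. Compound 2 already holds 2,6-difluorophenyl on a differing core, and its value of 39000 nM does not stand apart from compound 3. The step of a 1.3-fold higher number from compound 3 to compound 4 (0.10 log units; within the scatter) is therefore expected to stay within the scatter in this assay. For compound 4 the estimated value is 25000 nM, with an expected range of 12000 nM to 52000 nM.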

Compound 4, half-maximal cytotoxic concentration: 65000 nM
The estimate for compound 4 lay 2.6-fold (0.41 log units) below the measured number; measured number above the stated range.
By their numbers in this assay, from the lowest: compounds 3, 2, 1 and 4 (each within the scatter of the next, the first and the last beyond it).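

In this assay the two groups on the carbonyl carbon hold the same atoms, yet 2,6-difluorophenyl in place of 2,4-difluorophenyl gives a 3.3-fold higher number from compound 3 to compound 4 (0.51 log units; beyond the scatter) and so shows that this position responds to the arrangement of the ring and not only to its make-up. Other changes stay small here: methyl in place of chloro on an aromatic carbon gives a 1.7-fold higher number from compound 2 to compound 4 (0.22 log units; within the scatter) and 2,6-difluorophenyl in place of 4-nitrophenyl gives a 1.1-fold higher number from compound 1 to compound 4 (0.05 log units; within the scatter) on the same carbonyl carbon. Nothing available accounts for the difference between the two difluorophenyl groups. As far as these compounds go, whether 2,6-dichlorophenyl or unsubstituted phenyl on this carbonyl carbon would sit with compound 3 or compound 4 remains open. So does whether the step between the two difluorophenyl groups holds with chloro in place of methyl.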